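Swapping the amide end of compound 3 for a hydroxyethyl chain

This account rests on a few compounds, and the source may have more. Where it says the series, first, only, none or still open, it means among the compounds named here.

Measured so far:
- compound 1, `CCNC(=O)CC1CCc2cc(OC)c(OC)cc21`: 33.3%
- compound 2, `CCN(CC)C(=O)CC1CCc2cc(OC)c(OC)cc21`: 16.7%
- compound 3, `COc1cc2c(cc1OC)C(CC(=O)N1CCNCC1)CC2`: 65%

All three share one core and differ only in the group on the amide carbonyl. In a functional assay on the whole organism (strain Wistar) for inhibition, with Rattus norvegicus as the target, read by paw edema, with stated times of 60 min and 24 h, at a dose of 100 mg/kg by the oral route (a higher number here means more inhibition at the dose given (going by the name of the read-out), a lower number less inhibition), compound 3 gives the highest number of the three, and both gaps to it lie beyond the scatter: a number 31.7 percentage points higher from compound 1 to compound 3 (beyond the scatter) and a number 48.3 percentage points higher from compound 2 to compound 3 (beyond the scatter). Between the two open-chain amides, a number 16.6 percentage points lower from compound 1 to compound 2 (beyond the scatter).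

Compound 4, `COc1cc2c(cc1OC)C(CC(=O)NCCO)CC2`, has not yet been measured. It differs from compound 3 in one place: (2-hydroxyethyl)amino in place of piperazin-1-yl on a carbonyl carbon. For the measured compounds named here, no measured pair shows this exact exchange, but two steps bear on it. The step from compound 1 to compound 3 shows that a ring-type amine on the carbonyl carbon sits far above ethylamino, and the step from compound 2 to compound 3 points the same way. Compound 4 returns to an open chain on that carbonyl, close in shape to compound 1, with a hydroxyl added. Reading these steps backwards, a drop from compound 3 is expected, of a size near a number 25 percentage points lower from compound 3 to compound 4 (beyond the scatter), landing compound 4 at an estimated 40% (range 20% to 60%).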

Compound 4, a percentage reported as inhibition, in the whole organism at one dose (the size of the read-out at that dose, not a potency): 13.3%
The estimate for compound 4 lay 26.7 percentage points above the measured number, and the stated range ends above it.
By their numbers in this assay, from the lowest: compounds 4 and 2 (each within the scatter of the next); then compound 1; then compound 3.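

Placing (2-hydroxyethyl)amino on the carbonyl carbon brings no recovery towards the piperazin-1-yl amide in this assay: the exchange gives a number 51.7 percentage points lower from compound 3 to compound 4 (beyond the scatter), so compound 3 remains clearly the highest of the four. The hydroxyl itself can be read from the closest open-chain pair, and adding it to the ethyl group gives a number 20 percentage points lower from compound 1 to compound 4 (beyond the scatter), so on this chain the change goes with less inhibition, not more. Set against diethylamino, the same chain gives a number 3.4 percentage points lower from compound 2 to compound 4 (within the scatter), which shows that two quite different open-chain groups can land at a similar level, while compound 1 shows that open chains on this carbonyl do not all read alike.

No measurement at hand gives a reason for any of these steps. From the compounds shown here alone, it also remains open whether the high number of compound 3 depends on the six-membered ring or on its second nitrogen, a question that a piperidine amide, with carbon at that place, or a morpholine amide, with oxygen there, would help to separate.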